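This account rests on a few compounds, and the source may have more. Where it says the series, first, only, none or still open, it means among the compounds named here.

Compound 1 `O=C(O)c1cc(-c2cccc(COc3ccc4c(=O)n(C5CCC5)sc4c3)c2)ccc1Cl` is one of two compounds with a number in an ADME assay on microsomes from liver (Rattus norvegicus) for metabolic stability, read by LC-MS, with a stated time of 1 h, at 37 degrees C, tested at 4 uM; a lower number here means that less of the compound is left, a higher number that more of the compound is left: compound 1 gives 67%, and compound 3 `O=C(O)c1cc(-c2cccc(COc3ccc4c(=O)n(C5CCCC5)sc4c3)c2)ccc1F` gives 71%, a gap that falls within the scatter, so neither can be called the more stable of the pair. Compound 2 `O=C1c2ccc(OCc3cccc(-c4ccc(C(F)(F)F)cc4F)c3)cc2CN1C1CCCC1` gives "not determined" (no result reported) in this assay, that is, no result. Compound 1 thus holds the lower of the two numbers, but only nominally. Compound 4 `CC(C)CCn1sc2cc(OCc3cccc(-c4ccc(Cl)c(C(=O)O)c4)c3)ccc2c1=O` keeps the core of compound 1 and differs in one place: isopentyl in place of cyclobutyl on an aromatic nitrogen. Among the compounds with values here, with no measured step to build on, the author expects only a small downward step, a number 12 percentage points lower from compound 1 to compound 4 (beyond the scatter), near the edge of the scatter. For compound 4 the estimate in this assay is 55%, within a range from 35% to 75%.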

Compound 4, percent of the compound remaining: 92%
For compound 4 the middle estimate is 37 percentage points below the measured one, and the stated range ends below it.
By their numbers in this assay, from the lowest: compounds 1 and 3 (each within the scatter of the next); then compound 4.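

Isopentyl in place of cyclobutyl on an aromatic nitrogen, next to the ring sulfur, gives a number 25 percentage points higher from compound 1 to compound 4 (beyond the scatter) in this assay. This single step shows that the group on this nitrogen can move the amount of compound left by more than the scatter, with the chain that has no ring on the higher side. Nothing measured here accounts for the step.

On these data alone, whether the missing ring or the chain itself matters stays open from this one pair. A shorter chain such as propyl, or an ether chain on the same nitrogen, would bear on that.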